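Swapping Fluoro for Nitro in a Cytotoxicity Series

The compounds below may be only part of what the source reports. "The series", "measured", "known", "first", "only" and "open" are said of these compounds alone.

Three compounds share one shape: compound 1 `C/C(=C\c1cc(-c2ccc(C)nc2)co1)C(N)=O`, compound 2 `C/C(=C\c1cc(-c2ccc(F)cc2)cs1)C(N)=O` and compound 3 `C/C(=C\c1nc(-c2ccc(C)cc2)cs1)C(N)=O`, all tested in a functional assay on A549 cells (Homo sapiens) for cytotoxicity, read by CCK-8 assay, with a stated time of 24 h; a higher number here means a weaker inhibitor, a lower number a stronger inhibitor. In this assay compound 1 reached only the limit of > 50000 nM. Compound 3 likewise gave only the limit of > 50000 nM. For compound 2 the result is again just the limit of > 50000 nM, so no number is known for it. No ranking is possible, since every value shown sits at the limit of > 50000 nM in this assay, at which 3 of the 3 values shown sit. Compound 4 `C/C(=C\c1cc(-c2ccc([N+](=O)[O-])cc2)cs1)C(N)=O` differs from compound 2 by nitro in place of fluoro on an aromatic carbon. Going by the values given here, no measured pair shows what such a swap does here, so the step from compound 2 to compound 4 is expected to stay within the scatter, about a step that the limit leaves unreadable from compound 2 to compound 4. Compound 4 is therefore estimated at 60000 nM, within 15000 nM to 250000 nM, most likely reported again only as a limit.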

Compound 4, half-maximal inhibitory concentration: 3500 nM
Beside the measured number, compound 4's estimate is 17-fold (1.23 log units) above it; the measured number lies below the stated range.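

In this assay, nitro in place of fluoro on an aromatic carbon, para to a large group, gives an at least 14-fold lower number from compound 2 to compound 4 (1.15 log units; beyond the scatter). This position is therefore not silent: one change there brings a compound into the range where the assay returns a number. The true size of the step stays unknown, because compound 2 gives only a limit: the limit of > 50000 nM in this assay, at which 3 of the 4 values shown sit.

From the compounds shown here alone, it remains open whether an amine, a nitrile or a carboxylic acid at this position would act as nitro does. Going by these compounds, whether nitro would do the same on the core of compound 3 also remains open.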